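From Amide to Ester at the Chain End

A few compounds are considered here, and "the series" means these few. Any claim that something is new, unique, unknown or untested is made for them only; others in the source may bear on it.

Of the compounds shown here, two have numbers so far in a functional assay on NCI-H460 cells (Homo sapiens) for inhibition, read by sulforhodamine B assay, with a stated time of 48 h; on this read-out higher numbers stand for weaker inhibition of growth and lower numbers for stronger inhibition of growth. Compound 1 (`CCCCCCCCCCCC[C@@H](O)[C@H]1CC[C@H]([C@H](O)CCCCCCCCCCNCc2ccnn2C)O1`) gives 1700 nM, while compound 2 (`CCCCCCCCCCCC[C@@H](O)[C@H]1CC[C@H]([C@H](O)CCCCCCCCCCC(=O)Nc2ccnn2C)O1`) gives 100000 nM, the higher of the two and so the weaker inhibition of growth. Among the compounds with values here, the only measured step, a 59-fold higher number from compound 1 to compound 2 (1.77 log units; beyond the scatter), is large and shows that changes at this end of the long chain can move the number strongly. Compound 3 (`CCCCCCCCCCCC[C@@H](O)[C@H]1CC[C@H]([C@H](O)CCCCCCCCCCOC(=O)c2ccnn2C)O1`) changes the same end again: ((1-methyl-1H-pyrazol-5-yl)carbonyl)oxy in place of (1-methyl-1H-pyrazol-5-yl)carbamoyl on a saturated chain carbon, ten or more bonds along the chain from an oxygen on a saturated carbon and a saturated ring carbon. That step involved no ester, so it suggests that a sizeable move is possible but fixes no direction firmly. Within the data shown here, with compound 2 already the higher of only two numbers at 100000 nM, a modest fall seems more likely than a further rise, and the expected step is a 3.3-fold lower number from compound 2 to compound 3 (0.52 log units; beyond the scatter). Compound 3 is estimated at 30000 nM, within an expected range of 5000 nM to 100000 nM.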

Compound 3, concentration for 50% growth inhibition: 34700 nM
Compound 3: the middle estimate sits 1.2-fold (0.06 log units) below what was measured; measured number inside the range.
By their numbers in this assay, from the lowest: compound 1; then compound 3; then compound 2.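

Replacing the amide link with an ester gives a 2.9-fold lower number from compound 2 to compound 3 (0.46 log units; beyond the scatter) in this assay, so even a swap that removes the amide hydrogen and keeps the (1-methyl-1H-pyrazol-5-yl) group moves the number measurably at this chain end. The ester still leaves a wide gap to the amine, with a 20-fold higher number from compound 1 to compound 3 (1.31 log units; beyond the scatter), so among these three compounds only the ((1-methyl-1H-pyrazol-5-yl)methyl)amino end gives a low number, and both carbonyl-containing links stay far higher. No measurement here accounts for these differences.

Compounds 2 and 3 both carry a carbonyl that compound 1 lacks, but they also differ from it in how the chain is joined, so the two features cannot be separated. An ether link at the same chain end, or a tertiary amine with a methyl on the nitrogen, could help show which feature matters.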